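The source may report more compounds than this note shows. Statements on the series, on what has been measured and on what is new or still open speak of the compounds shown alone.

Compound 1 `COc1cccc(C2=NN(C(=S)Nc3ccccc3)C(c3ccc4c(c3)OCCO4)C2)c1` and compound 2 `S=C(Nc1ccccc1)N1N=C(c2ccc(Cl)c(Cl)c2)CC1c1ccc2c(c1)OCCO2` share one core and differ only in the aryl group on a carbon with a double bond to nitrogen. In a functional assay on HCT-116 cells (Homo sapiens) for antiproliferative activity, read by MTT assay, with a stated time of 48 h (a lower number here means a stronger inhibitor of growth, a higher number a weaker inhibitor of growth), compound 1 gives only a limit of the assay, > 200000 nM. In this assay, among the compounds with values here, compound 2 gives 125000 nM, the only number among the two values shown. Of the two values shown, that of compound 1 is a limit (the limit of > 200000 nM in this assay, at which 1 of the 2 values shown sits). The step of an at least 1.6-fold lower number from compound 1 to compound 2 (0.20 log units; that floor lies within the scatter) is therefore bounded on one side only.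

Compound 3 `Cc1ccc(C2=NN(C(=S)Nc3ccccc3)C(c3ccc4c(c3)OCCO4)C2)cc1C` is not yet measured. It differs from compound 2 in one place: 3,4-dimethylphenyl in place of 3,4-dichlorophenyl on a carbon with a double bond to nitrogen. Within the data shown here, no measured step exchanges one aryl group for another where both compounds carry a number; the single step at this position, an at least 1.6-fold lower number from compound 1 to compound 2 (0.20 log units; that floor lies within the scatter), has a floor that lies within the scatter. Nothing in the data separates 3,4-dimethylphenyl from 3,4-dichlorophenyl. Compound 3 is therefore expected, in this assay, to show a step of a 1.2-fold higher number from compound 2 to compound 3 (0.08 log units; within the scatter) that stays within the scatter. The estimate for compound 3 in this assay is 150000 nM, within 60000 nM to 400000 nM.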

Compound 3, concentration for 50% growth inhibition: 144000 nM
Beside the measured number, compound 3's estimate is 1.0-fold (0.02 log units) above it, and the stated range covers the measured number.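

In this assay, within the data shown here, the exchange of 3,4-dichlorophenyl for 3,4-dimethylphenyl gives the first step at this position with a number on both sides, a 1.2-fold higher number from compound 2 to compound 3 (0.06 log units; within the scatter). The two aryl groups, each with the same count of heavy atoms, are thus not told apart here, even though two chlorine atoms give way to two carbon atoms. The step of an at least 1.3-fold lower number from compound 1 to compound 3 (0.14 log units; that floor lies within the scatter) adds little about 3-methoxyphenyl against 3,4-dimethylphenyl, as it is bounded on one side only and compound 1 stands at a limit of the assay: the limit of > 200000 nM in this assay, at which 1 of the 3 values shown sits.

The compounds shown leave open whether any group on this carbon would move the number beyond the scatter, for instance an aryl group carrying an amine or a carboxylic acid, or a longer alkyl chain in place of the aryl group. They also leave open what a change would do at the 2,3-dihydro-1,4-benzodioxin-6-yl group or the group of 9 heavy atoms, both of which stay the same in all three compounds.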